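This account rests on a few compounds, and the source may have more. Where it says the series, first, only, none or still open, it means among the compounds named here.

Values from a functional assay on HCT-116 cells (Homo sapiens) for antiproliferative activity, read by WST assay, with a stated time of 72 h (on this read-out lower numbers stand for stronger inhibition of growth and higher numbers for weaker inhibition of growth), so far:

- compound 1 `O=C(NO)c1cnc(N2C[C@@H]3[C@H](C2)[C@H]3NCc2ccccc2)nc1` gives 120 nM
- compound 2 `O=C(NO)c1cnc(N2C[C@@H]3[C@H](C2)[C@H]3NCC2CCCCC2)nc1` gives 160 nM
- compound 3 `O=C(NO)c1cnc(N2C[C@@H]3[C@H](C2)[C@H]3NCc2ccc(OC(F)(F)F)cc2)nc1` gives 120 nM

Compound 3 stands level with compound 1 at the digits shown, and compound 2 lies within the scatter of both. The next compound to be read is compound 4 (`COc1ccc(CN[C@H]2[C@@H]3CN(c4ncc(C(=O)NO)cn4)C[C@@H]32)cc1`). The change from compound 3 is methyl in place of trifluoromethyl on an oxygen on an aromatic ring and amounts to methyl in place of trifluoromethyl on an oxygen on an aromatic ring, so trifluoromethoxy becomes methoxy.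

Among the measured compounds shown here, two measured steps bear on this change. Trifluoromethoxy in place of hydrogen on an aromatic carbon gave no change at the digits printed from compound 1 to compound 3 (within the scatter) and stayed within the scatter. Cyclohexyl in place of phenyl on a saturated chain carbon bound to an amine nitrogen gave a 1.3-fold higher number from compound 1 to compound 2 (0.12 log units; within the scatter) and also stayed within the scatter. For the measured compounds named here, no measured step exchanges trifluoromethyl for methyl directly, so the evidence is indirect. Going by the values given here, still, neither measured change moved the number beyond the scatter in this assay so far.

The expected result is no change at the digits printed from compound 3 to compound 4 (within the scatter) and no step beyond the scatter is anticipated in either direction. For compound 4 a value of 120 nM is expected, with 65 nM to 220 nM as the estimated range.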

Compound 4, concentration for 50% growth inhibition: 190 nM
The estimate for compound 4 lay 1.6-fold (0.20 log units) below the measured number, and the stated range covers the measured number.
By their numbers in this assay, from the lowest: compounds 1, 3, 2 and 4 (each within the scatter of the next).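

In this assay, methyl in place of trifluoromethyl on the oxygen on an aromatic ring gives a 1.6-fold higher number from compound 3 to compound 4 (0.20 log units; within the scatter), and methoxy in place of hydrogen on an aromatic carbon gives a 1.6-fold higher number from compound 1 to compound 4 (0.20 log units; within the scatter); hydrogen, trifluoromethoxy and methoxy therefore cannot be told apart on this read-out, and the oxygen substituent has now been varied without any step leaving the scatter. Replacing cyclohexyl with 4-methoxyphenyl on the saturated chain carbon bound to the amine nitrogen gives a 1.2-fold higher number from compound 2 to compound 4 (0.07 log units; within the scatter), so this substituted aromatic group also cannot be separated from the saturated ring. No measurement is available that would account for any of these steps.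

The compounds shown leave open whether a carboxylic acid or an amine on the aromatic ring, or a longer chain to the amine nitrogen, would produce a step beyond the scatter. As far as these compounds go, all four compounds share the same core, so what a change to that core would do to growth inhibition also remains open.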